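The source may report more compounds than this note shows. Statements on the series, on what has been measured and on what is new or still open speak of the compounds shown alone.

Compound 1 `CCCCOc1ccc(C(=O)/C=C/c2c(/C=C/c3ccc(OC)cc3)cc(OC)cc2OC)cc1` gives 8.7 ug/mL
Compound 2 `COc1ccc(/C=C/c2cc(OC)cc(OC)c2/C=C/C(=O)c2cccc(Br)c2)cc1` gives 8.1 ug/mL
Compound 3 `COc1ccc(/C=C/c2cc(OC)cc(OC)c2/C=C/C(=O)c2ccc(Cl)cc2)cc1` gives 6.4 ug/mL

These three compounds were tested in a functional assay on A549 cells (Homo sapiens) for antiproliferative activity, read by MTT assay, with a stated time of 48 h; on this read-out lower numbers stand for stronger inhibition and higher numbers for weaker inhibition. Compound 2 stands second highest of the three numbers, with compound 1 nearest and compound 3 furthest, and every gap among the three lies within the scatter. The unmeasured compound 4 `COc1ccc(/C=C/c2cc(OC)cc(OC)c2/C=C/C(=O)c2ccc(C)cc2C)cc1` differs from compound 2 only at the ring attached to the carbonyl carbon: 2,4-dimethylphenyl in place of 3-bromophenyl on a carbonyl carbon. Within the data shown here, two measured steps bear on this kind of change, since each also exchanges the ring on the carbonyl carbon: a 1.1-fold lower number from compound 1 to compound 2 (0.03 log units; within the scatter) and a 1.3-fold lower number from compound 2 to compound 3 (0.10 log units; within the scatter). The remaining step, a 1.4-fold lower number from compound 1 to compound 3 (0.13 log units; within the scatter), exchanges a single group on that ring and is likewise small. So far, changing this ring has not moved the number beyond the scatter, and no measured step involves a 2,4-dimethylphenyl ring. In this assay compound 4 is therefore expected to show a 1.0-fold lower number from compound 2 to compound 4 (0.01 log units; within the scatter). For compound 4 the estimate is 8 ug/mL, with a range from 4 ug/mL to 16 ug/mL.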

Compound 4, half-maximal inhibitory concentration: 0.3 ug/mL
Beside the measured number, compound 4's estimate is 27-fold (1.43 log units) above it, outside the stated range (below it).
By their numbers in this assay, from the lowest: compound 4; then compounds 3, 2 and 1 (each within the scatter of the next).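

In this assay the ring on the carbonyl carbon proves able to move the number strongly, although the 3-bromophenyl, 4-chlorophenyl and 4-butoxyphenyl rings all stayed within the scatter of one another. Among these compounds, putting 2,4-dimethylphenyl in their place gives a 27-fold lower number from compound 2 to compound 4 (1.43 log units; beyond the scatter) and a 21-fold lower number from compound 3 to compound 4 (1.33 log units; beyond the scatter) and a 29-fold lower number from compound 1 to compound 4 (1.46 log units; beyond the scatter) with the rest of the molecule unchanged, so this position is not as insensitive as the earlier compounds suggested. Nothing available accounts for why this ring stands so far apart from the other three.

As far as these compounds go, it remains open whether both methyl groups of the 2,4-dimethylphenyl ring are needed or whether one alone would give the same result. Also unsettled is how an ethyl group or an amine on this ring would compare.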